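From propyl to butyl on compound 2

The source may hold more compounds than are shown below. What is called first, only, known or untested is meant among the compounds shown, and "the series" means these compounds.

In a functional assay on the whole organism for inhibition, with Rattus norvegicus as the target (a higher number here means that more compound is needed for the effect, a lower number that less compound is needed), compound 1 `CC(C)c1ccc(OC(C)(Cc2ccccc2)C(=O)O)cc1` gives > 10 mg/kg, which is a limit and not a number. Among the measured compounds shown here, compound 2 `CCCc1cccc(CC(C)(Oc2ccc(C(C)C)cc2)C(=O)O)c1` gives 1 mg/kg, the only true number so far. Its added propyl produced an at least 10-fold lower number from compound 1 to compound 2 (1.00 log units; beyond the scatter). Compound 3 `CCCCc1cccc(CC(C)(Oc2ccc(C(C)C)cc2)C(=O)O)c1` lengthens propyl to butyl: methyl in place of hydrogen on a saturated chain carbon, three bonds along the chain from an aromatic carbon. For the measured compounds named here, that measured step, an at least 10-fold lower number from compound 1 to compound 2 (1.00 log units; beyond the scatter), is the only guide, and adding one methyl is a smaller change, so only a slight drop, within the scatter, is expected. The expected step is a 1.4-fold lower number from compound 2 to compound 3 (0.15 log units; within the scatter). For compound 3, the estimated dose is 0.7 mg/kg, ranging from 0.2 mg/kg to 3 mg/kg.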

Compound 3, dose for half-maximal effect: 1 mg/kg
Beside the measured number, compound 3's estimate is 1.4-fold (0.15 log units) below it; the range from low to high includes it.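

In this assay, lengthening the chain at this position from propyl to butyl gives no change at the digits printed from compound 2 to compound 3 (within the scatter), so the added methyl neither helps nor harms measurably. Butyl in place of hydrogen keeps the gain that propyl brought, with an at least 10-fold lower number from compound 1 to compound 3 (1.00 log units; beyond the scatter). The true size of that gain stays open, as compound 1 carries a limit and not a number: the limit of > 10 mg/kg in this assay, at which 1 of the 3 values shown sits.

With only propyl and butyl shown at this position, it remains open whether a longer chain such as hexyl, or a chain ending in an amine, would hold the dose or shift it. As far as these compounds go, whether a shorter ethyl chain would already be enough is equally open.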